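The compounds below may be only part of what the source reports. "The series", "measured", "known", "first", "only" and "open" are said of these compounds alone.

Compound 1, `Cc1nc(S(C)(=O)=O)ccc1Oc1ncnc(OC2CCN(C(=O)OC3CCC3)CC2)c1F`, gives 13.6 nM in a functional assay on isolated protein for inhibition of Glucose-dependent insulinotropic receptor (Homo sapiens), read by HTRF and cAMP accumulation; a lower number here means that less compound is needed, a higher number that more compound is needed for the effect.
Compound 2, `Cc1nc(S(C)(=O)=O)ccc1Oc1ncnc(OC2CCN(C(=O)OC(C)(C)CF)CC2)c1F`, gives 19.9 nM.
Compound 3, `Cc1nc(S(C)(=O)=O)ccc1Oc1ncnc(OC2CCN(C(=O)OC3(C(F)(F)F)COC3)CC2)c1F`, gives 29.3 nM.

All three share one core and differ only in the group carried on the oxygen that sits on a carbonyl carbon whose other neighbour is an amide-type nitrogen in a ring. Compound 3 has the highest number of the three: it is separated from the nearest compound by a 1.5-fold higher number from compound 2 to compound 3 (0.17 log units; within the scatter), which is within the scatter, and from the furthest by a 2.2-fold higher number from compound 1 to compound 3 (0.33 log units; beyond the scatter), a modest difference.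

Compound 4, `Cc1nc(S(C)(=O)=O)ccc1Oc1ncnc(OC2CCN(C(=O)SC(C)(C)C)CC2)c1F`, changes this position in a new way: (tert-butyl)sulfanyl in place of (3-(trifluoromethyl)oxetan-3-yl)oxy on a carbonyl carbon. Among the compounds with values here, no measured step exchanges oxygen for sulfur at that carbonyl. Within the data shown here, the steps that bear on it only vary the group beyond the oxygen, and they are small: a 1.5-fold higher number from compound 1 to compound 2 (0.17 log units; within the scatter) and a 2.2-fold higher number from compound 1 to compound 3 (0.33 log units; beyond the scatter). Across three different groups at this position the numbers in this assay stayed close together, so a small step is expected here too, though the swap to sulfur and a tert-butyl adds uncertainty. The step expected is a 1.5-fold lower number from compound 3 to compound 4 (0.17 log units; within the scatter). Compound 4 is therefore estimated at 20 nM, with a range from 7 nM to 60 nM.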

Compound 4, half-maximal effective concentration: 4.83 nM
For compound 4 the middle estimate is 4.1-fold (0.62 log units) above the measured one; measured number outside the range, below it.
By their numbers in this assay, from the lowest: compound 4; then compounds 1, 2 and 3 (each within the scatter of the next, the first and the last beyond it).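

In this assay, (tert-butyl)sulfanyl on the carbonyl carbon gives the lowest number of the four compounds, with a 6.1-fold lower number from compound 3 to compound 4 (0.78 log units; beyond the scatter), a 4.1-fold lower number from compound 2 to compound 4 (0.61 log units; beyond the scatter) and a 2.8-fold lower number from compound 1 to compound 4 (0.45 log units; beyond the scatter), all printed as beyond the scatter. Within the data shown here, the earlier compounds showed only that changing the group beyond the oxygen moved the number little, whereas this result shows that a change at this position that also replaces that oxygen with sulfur can lower the number beyond the scatter from every earlier compound. Nothing measured here explains this result.

From the compounds shown here alone, compound 4 differs from the others both in the atom on the carbonyl carbon and in the group beyond it, so the shares of the sulfur and the tert-butyl remain unknown; tert-butyloxy or cyclobutylsulfanyl at the same place would separate them. Going by these compounds, it also remains open whether a nitrogen link, as in tert-butylamino on the carbonyl carbon, would give a number closer to that of compound 4 or to those of the three oxygen-linked compounds.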